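This account rests on a few compounds, and the source may have more. Where it says the series, first, only, none or still open, it means among the compounds named here.

Measured in a functional assay on HeLa cells (Homo sapiens) for cytotoxicity, read by WST assay, with a stated time of 48 h; a lower number here means a stronger inhibitor, a higher number a weaker inhibitor:
Compound 1 `Oc1ccccc1/C=C/C[C@H]1C[C@@H]([C@@H](O)c2ccccc2)CO[C@@H]1c1ccccc1`: 21800 nM
Compound 2 `COc1ccc(/C=C/C[C@H]2C[C@@H]([C@@H](O)c3ccccc3)CO[C@@H]2c2ccccc2)cc1`: 8300 nM
Compound 3 `O=[N+]([O-])c1cccc(/C=C/C[C@H]2C[C@@H]([C@@H](O)c3ccccc3)CO[C@@H]2c2ccccc2)c1`: 7850 nM

The three compounds differ only in the aromatic group at the end of the unsaturated chain. Compound 3 shares the low end of these numbers with its nearest neighbour, and that gap stays within the scatter: a 1.1-fold lower number from compound 2 to compound 3 (0.02 log units; within the scatter). Its gap to the remaining compound is modest but beyond the scatter: a 2.8-fold lower number from compound 1 to compound 3 (0.44 log units; beyond the scatter).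

The next compound is compound 4 `O[C@@H](c1ccccc1)[C@H]1CO[C@H](c2ccccc2)[C@@H](C/C=C/c2cccnc2)C1`, which has not yet been measured. It carries pyridin-3-yl in place of 3-nitrophenyl on a double-bonded chain carbon bound to a double-bonded chain carbon.

All three measured steps were made at this same place. The two that leave the scatter both start from compound 1, and the second of them is matched by a 2.6-fold lower number from compound 1 to compound 2 (0.42 log units; beyond the scatter). Between the two other groups, the exchange produced no step beyond the scatter. Among the measured compounds shown here, no measured compound carries a pyridine ring, so this evidence is indirect. In this assay, no step beyond the scatter is therefore expected, with only a slight lean towards a higher number.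

The estimated change is a 1.3-fold higher number from compound 3 to compound 4 (0.11 log units; within the scatter).

For compound 4, the expected value is 10000 nM, with an estimated range of 4500 nM to 22000 nM.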

Compound 4, half-maximal inhibitory concentration: > 100000 nM
Compound 4 gave a limit, no number; the forecaster's own chance of this, stated with the estimate: 10%; middle value at least 10-fold (1.00 log units) from the limit.
By their numbers in this assay, from the lowest: compounds 3 and 2 (each within the scatter of the next); then compound 1. At a limit, above all of these: compound 4.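

In this assay compound 4, with pyridin-3-yl at the end of the unsaturated chain, gave a limit and no number: the limit of > 100000 nM in this assay, at which 1 of the 4 values shown sits.

The earlier exchanges at this place, on a double-bonded chain carbon bound to a double-bonded chain carbon, were modest or stayed within the scatter, whereas this one gives an at least 12-fold higher number from compound 3 to compound 4 (1.10 log units; beyond the scatter) and an at least 12-fold higher number from compound 2 to compound 4 (1.08 log units; beyond the scatter), and even the smallest of the new steps is an at least 4.5-fold higher number from compound 1 to compound 4 (0.66 log units; beyond the scatter). Among the compounds shown here, the position is therefore far less forgiving than the first three compounds suggested: all three carried a substituted phenyl ring there and gave numbers, while pyridin-3-yl, the only ring here with a hetero atom, is the one group of the four that ends at a limit.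

Whether this step goes with the ring nitrogen or with the loss of any substituent on the ring stays open, as neither an unsubstituted phenyl ring nor a pyridine ring bearing a methoxy group is among the compounds shown. Going by these compounds, how far the true value of compound 4 lies past its limit also remains open.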